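The source may hold more compounds than are shown below. What is called first, only, known or untested is meant among the compounds shown, and "the series" means these compounds.

Measured so far in an ADME assay on HEL cells (Homo sapiens) for cytotoxicity, with a stated time of 3 days; on this read-out higher numbers stand for lower toxicity in this test and lower numbers for higher toxicity in this test:
compound 1 `c1ccc(CCSCc2cnc3ccc(-c4ccccc4)cn23)cc1`: 4 ug/mL
compound 2 `Cc1cc(-c2ccccc2)cn2c(CSCCc3ccccc3)cnc12`: 20 ug/mL

Among the compounds with values here, compound 2 holds the highest of the two numbers in this assay; the only measured step, a 5.0-fold higher number from compound 1 to compound 2 (0.70 log units; beyond the scatter), concerns a methyl in place of hydrogen and is modest. Compound 3 `Cc1cc(-c2ccsc2)cn2c(CSCCc3ccccc3)cnc12` differs from compound 2 by thiophen-3-yl in place of phenyl on an aromatic carbon. Within the data shown here, no measured step touches a change of the phenyl group, so that single step gives no guidance on this exchange. Compound 3 is therefore expected to move only within the scatter, no change at the digits printed from compound 2 to compound 3 (within the scatter). For compound 3 the estimate in this assay is 20 ug/mL, with a range from 8 ug/mL to 50 ug/mL.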

Compound 3, minimum cytotoxic concentration: >= 4 ug/mL
Compound 3: only a limit was reported (the forecaster's own chance of this, stated with the estimate: 20%); the middle value lies beyond the limit too.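

For compound 3 the result is only a limit, >= 4 ug/mL, so the step from compound 2 to compound 3 cannot be read in this assay. Going by these compounds, whether thiophen-3-yl in place of phenyl changes the read-out remains open.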